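The source may report more compounds than this note shows. Statements on the series, on what has been measured and on what is new or still open speak of the compounds shown alone.

Compound 1 `COc1ccc(NC(=O)CN2CCN(c3nnc(Cc4ccncc4)c4ccccc34)CC2)cc1OC`: 100 nM
Compound 2 `O=C(CN1CCN(c2nnc(Cc3ccncc3)c3ccccc23)CC1)Nc1cc(C(F)(F)F)ccc1Cl`: 3.7 nM

In a functional assay on MDA-MB-231 cells (Homo sapiens) for cytotoxicity, read by MTT assay, with a stated time of 72 h (a lower number here means a stronger inhibitor, a higher number a weaker inhibitor), compound 2 holds the lower of the two numbers, at 3.7 nM. Compound 3 `O=C(CN1CCN(c2nnc(Cc3ccncc3)c3ccccc23)CC1)Nc1c(F)cccc1F` differs from it by 2,6-difluorophenyl in place of 2-chloro-5-(trifluoromethyl)phenyl on an amide-type nitrogen, with 2,6-difluorophenyl in place of 2-chloro-5-(trifluoromethyl)phenyl on an amide-type nitrogen. Within the data shown here, one measured step bears on this place, and it is large: a 27-fold lower number from compound 1 to compound 2 (1.43 log units; beyond the scatter). Compound 3 carries neither of the groups compared in that step, so it gives the size of possible change, not its direction. A moderate move toward a higher number is expected, with the estimated step being a 4.1-fold higher number from compound 2 to compound 3 (0.61 log units; beyond the scatter). Compound 3 is expected at 15 nM, in an estimated range of 3 nM to 80 nM.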

Compound 3, half-maximal inhibitory concentration: 1900 nM
Compound 3: middle estimate off by 130-fold (2.10 log units), on the low side; the measured number lies above the stated range.
By their numbers in this assay, from the lowest: compound 2; then compound 1; then compound 3.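

In this assay, the aryl group on this amide-type nitrogen matters even more than the first pair showed: the full span is larger (a 510-fold higher number from compound 2 to compound 3 (2.71 log units; beyond the scatter)). 2,6-Difluorophenyl also falls behind 3,4-dimethoxyphenyl (a 19-fold higher number from compound 1 to compound 3 (1.28 log units; beyond the scatter)), so compound 3 holds the highest number of the three. Nothing available accounts for these differences.

The compounds shown leave open whether the chlorine or the trifluoromethyl group of compound 2 carries its low number. Also open, going by these compounds, is what a phenyl bearing an amine or a carboxylic acid would give.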